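Furan for Methoxyphenyl, Tried on Two Prenylated Cores

The source may report more compounds than this note shows. Statements on the series, on what has been measured and on what is new or still open speak of the compounds shown alone.

Compound 1 `COc1ccc(C(=O)NCCCOc2cc(=O)n(CCCO)c3c2CC(CC=C(C)C)C(C)(C)C3)cc1`: 2.5%
Compound 2 `CC(C)=CCC1Cc2c(OCCCNC(=O)c3ccco3)cc(=O)n(CCCO)c2CC1(C)C`: 4.3%
Compound 3 `COc1ccc(C(=O)NCCCOc2cc(=O)n(CCCO)c3c2CC(C/C=C(\C)CCC=C(C)C)C(C)(C)C3)cc1`: 14.1%

Of the compounds shown here, three have been measured in a functional assay on PANC-1 cells (Homo sapiens) for inhibition, read by MTT assay, with a stated time of 24 h, tested at 10 uM; a higher number here means more inhibition at the concentration tested (going by the name of the read-out), a lower number less inhibition. Compound 1 gives 2.5%, compound 2 gives 4.3%, and compound 3 gives 14.1%. Compound 2 arises from compound 1 by furan-2-yl in place of 4-methoxyphenyl on a carbonyl carbon, and the step is a number 1.8 percentage points higher from compound 1 to compound 2 (within the scatter). Compound 3 arises from compound 1 by 3-methylbut-2-en-1-yl in place of hydrogen on a saturated chain carbon bound to a double-bonded chain carbon, with the step of a number 11.6 percentage points higher from compound 1 to compound 3 (beyond the scatter). Compound 4 `CC(C)=CCC/C(C)=C/CC1Cc2c(OCCCNC(=O)c3ccco3)cc(=O)n(CCCO)c2CC1(C)C` is not yet measured; it differs from compound 3 by furan-2-yl in place of 4-methoxyphenyl on a carbonyl carbon, the same change as that between compound 1 and compound 2, now made on the core of compound 3. The expectation rests on that earlier pair, compound 1 and compound 2, whose step is a number 1.8 percentage points higher from compound 1 to compound 2 (within the scatter). For compound 4 a step of similar size is expected in this assay, namely a number 1.9 percentage points higher from compound 3 to compound 4 (within the scatter). Compound 4 is therefore estimated at 16%, expected to lie between 5% and 27%.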

Compound 4, a percentage reported as inhibition, at one concentration (the size of the read-out at that concentration, not a potency): 2.8%
Compound 4: middle estimate off by 13.2 percentage points, on the high side; the measured number lies below the stated range.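

In this assay, furan-2-yl in place of 4-methoxyphenyl on a carbonyl carbon gives a number 11.3 percentage points lower from compound 3 to compound 4 (beyond the scatter), and the added 3-methylbut-2-en-1-yl gives a number 1.5 percentage points lower from compound 2 to compound 4 (within the scatter). The furan change looks different on the two cores, yet the gap between its steps stays within what two such steps can scatter: the same change on two cores in this assay, a number 1.8 percentage points higher (within the scatter) from compound 1 to compound 2 and a number 11.3 percentage points lower (beyond the scatter) from compound 3 to compound 4, 13.1 percentage points apart, within the scatter of two such steps. The same holds for the added chain, so these compounds show neither that either change carries from one core to the other nor that it fails to: the same change on two cores in this assay, a number 11.6 percentage points higher (beyond the scatter) from compound 1 to compound 3 and a number 1.5 percentage points lower (within the scatter) from compound 2 to compound 4, 13.1 percentage points apart, within the scatter of two such steps.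

Left open is how a plain phenyl or a thiophene on that carbonyl carbon would read in this assay. Also open, as far as these compounds go, is whether an amine or a carboxylic acid there would give a step clear of the scatter on both cores.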